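The source may report more compounds than this note shows. Statements on the series, on what has been measured and on what is new or still open speak of the compounds shown alone.

Measured compounds:
Compound 1, `CC(CNCC1CCCC1)Oc1cccc2ccc(N)nc12`: 100 nM
Compound 2, `CC(CN1CCCC1)Oc1cccc2ccc(N)nc12`: 360 nM
Compound 3, `COc1cccc(CNCC(C)Oc2cccc3ccc(N)nc23)c1`: 600 nM

In a functional assay on IMR-32 cells with melanin-concentrating hormone receptor 1 (Homo sapiens) as the target, read by fluorescence (on this read-out higher numbers stand for weaker inhibition and lower numbers for stronger inhibition), compound 3 gives the highest of the three numbers; compound 2 lies within the scatter of it, while compound 1 stands well apart, as a 6.0-fold higher number from compound 1 to compound 3 (0.78 log units; beyond the scatter) shows. Compound 4, `CC(CNCc1ccoc1)Oc1cccc2ccc(N)nc12`, differs from compound 3 by furan-3-yl in place of 3-methoxyphenyl on a saturated chain carbon bound to an amine nitrogen. Among the compounds with values here, only one measured step touches this place, a 6.0-fold higher number from compound 1 to compound 3 (0.78 log units; beyond the scatter), and it compares cyclopentyl with 3-methoxyphenyl; the other step, a 3.6-fold higher number from compound 1 to compound 2 (0.56 log units; beyond the scatter), concerns a different place. Neither involves furan-3-yl, so the direction is open, though compound 1 shows that another group at this place gives a much lower number. Compound 4 is therefore expected to shift by a 1.5-fold lower number from compound 3 to compound 4 (0.18 log units; within the scatter) in this assay, with an estimate of 400 nM and a range from 130 nM to 1300 nM.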

Compound 4, half-maximal inhibitory concentration: 100 nM
Estimate against measurement, compound 4: 4.0-fold (0.60 log units) above; the whole stated range lies above it.
By their numbers in this assay, from the lowest: compounds 1 and 4 (each within the scatter of the next); then compounds 2 and 3 (each within the scatter of the next).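

In this assay, furan-3-yl gives a 6.0-fold lower number from compound 3 to compound 4 (0.78 log units; beyond the scatter) and, with no change at the digits printed from compound 1 to compound 4 (within the scatter), matches the low number seen with cyclopentyl, so an aromatic ring at this place does not by itself bring the higher number seen with 3-methoxyphenyl. ((Furan-3-yl)methyl)amino also separates from pyrrolidin-1-yl, with a 3.6-fold lower number from compound 2 to compound 4 (0.56 log units; beyond the scatter). No measurement here explains these differences. As far as these compounds go, it remains open whether the methoxy group or the six-membered ring of 3-methoxyphenyl accounts for its higher number, and how unsubstituted phenyl or furan-2-yl would read at this place.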